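This account rests on a few compounds, and the source may have more. Where it says the series, first, only, none or still open, it means among the compounds named here.

Compounds measured so far:
- compound 1 `Cc1cn(/C=C/C=O)c(=O)[nH]c1=O`: 23000 nM
- compound 2 `O=C/C=C/n1ccc(=O)[nH]c1=O`: 30000 nM
- compound 3 `O=C/C=C/n1cc(CO)c(=O)[nH]c1=O`: > 100000 nM (a limit of the assay, not a number)

In a functional assay on HeLa cells (Homo sapiens) for inhibition (on this read-out higher numbers stand for weaker inhibition and lower numbers for stronger inhibition), compound 1 gives 23000 nM, and its value cannot be told apart from that of compound 2, with a 1.3-fold higher number from compound 1 to compound 2 (0.12 log units; within the scatter). Compound 3 reads > 100000 nM, which is a limit. The steps to it are an at least 4.3-fold higher number from compound 1 to compound 3 (0.63 log units; beyond the scatter) and an at least 3.3-fold higher number from compound 2 to compound 3 (0.52 log units; beyond the scatter).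

Compound 4 `Cc1cn(/C=C/C=N/O)c(=O)[nH]c1=O` keeps the core of compound 1 but replaces the formyl group on a double-bonded chain carbon bound to a double-bonded chain carbon: a group of 3 heavy atoms (1 carbon, 1 nitrogen, 1 oxygen; no ring) in place of a group of 2 heavy atoms (1 carbon, 1 oxygen; no ring), on a double-bonded chain carbon bound to a double-bonded chain carbon. For the measured compounds named here, no measured step changes the formyl group, so the three steps bear on this change only indirectly. Going by the values given here, the only steps beyond the scatter, those ending at compound 3 with an at least 4.3-fold higher number from compound 1 to compound 3 (0.63 log units; beyond the scatter) and an at least 3.3-fold higher number from compound 2 to compound 3 (0.52 log units; beyond the scatter), run toward higher numbers, so a modest step in that direction is expected in this assay, with low confidence. The expected step is a 2.2-fold higher number from compound 1 to compound 4 (0.34 log units; beyond the scatter). For compound 4 the estimated value is 50000 nM, with an expected range from 16000 nM to 100000 nM.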

Compound 4, half-maximal inhibitory concentration: > 100000 nM
Compound 4: a limit, no number; the forecaster's own chance of this, stated with the estimate: 30%; at least 2.0-fold (0.30 log units) between middle value and limit.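

In this assay compound 4 reads > 100000 nM, which is a limit of the assay and not a number. For the compounds shown here, replacing the formyl group with the group of 3 heavy atoms, on a double-bonded chain carbon bound to a double-bonded chain carbon, gives an at least 4.3-fold higher number from compound 1 to compound 4 (0.63 log units; beyond the scatter), the first step at this position and one showing that this site does not tolerate every change in this assay. The full size of the step cannot be given, because the read-out stops at a limit: the limit of > 100000 nM in this assay, at which 2 of the 4 values shown sit.

Going by these compounds, whether a carboxylic acid or a nitrile in place of the formyl group would stay close to compound 1 or fall to the limit like compound 4 remains open. On these data alone, it is also open whether the same change would carry over to the core of compound 2.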